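Sec-butyl to isobutyl on the amine nitrogen: curcumin-type series

The source may report more compounds than this note shows. Statements on the series, on what has been measured and on what is new or still open speak of the compounds shown alone.

Measured compounds:
compound 1, `COc1cc(/C=C/C(=O)/C=C(/C=C/c2ccc(OC(C)=O)c(OC)c2)NC2CCCCC2)ccc1OC(C)=O`, 89%
compound 2, `CCC(C)NC(=C\C(=O)/C=C/c1ccc(O)c(OC)c1)/C=C/c1ccc(O)c(OC)c1`, 91%
compound 3, `CCC(C)NC(=C\C(=O)/C=C/c1ccc(O)cc1)/C=C/c1ccc(O)cc1`, 102%

All three have been run in a functional assay on Caco-2 cells (Homo sapiens), read by fluorescence, tested at 1 uM; on this read-out higher numbers stand for a weaker effect at the one concentration tested and lower numbers for a stronger effect. Compound 2 gives 91%. Compound 1 gives 89%, a number within the scatter of compound 2, so the two cannot be told apart on these data. Compound 3 gives 102%, a number higher than that of compound 2 and beyond the scatter; compound 3 also lacks the methoxy groups carried by compound 2, so this gap is not a single change.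

Compound 4, `COc1cc(/C=C/C(=O)/C=C(/C=C/c2ccc(O)c(OC)c2)NCC(C)C)ccc1O`, has not been measured. It differs from compound 2 in one place:
isobutyl in place of sec-butyl on an amine nitrogen
The two share every atom and differ only in how the four-carbon chain on the amine nitrogen is branched. Among the compounds with values here, no measured pair in this set isolates such a change.

Within the data shown here, with no comparable step recorded, the expectation is that the step of no change at the digits printed from compound 2 to compound 4 (within the scatter) stays within the scatter, in no preferred direction, because compound 2 gives 91% and the change alters no ring, donor, acceptor or charge. Compound 4 is therefore estimated at 91% in this assay, with a range from 79% to 103%.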

Compound 4, a percentage reported as activity, at one concentration (the size of the read-out at that concentration, not a potency): 91%
The estimate for compound 4 equals the measured number at the digits printed, and the stated range covers the measured number.
By their numbers in this assay, from the lowest: compounds 1, 2 and 4 (each within the scatter of the next); then compound 3.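

In this assay, within the data shown here, isobutyl in place of sec-butyl on the amine nitrogen gives no change at the digits printed from compound 2 to compound 4 (within the scatter), and this is the only comparison that differs in one place. At this position, a different branching of the four-carbon chain therefore leaves no readable mark on this read-out at the one concentration tested. Nothing available bears on why the read-out holds across this change.

Still open, on these data alone, is how the amine nitrogen responds to a group of another kind, such as a longer chain like n-octyl or a chain ending in a carboxylic acid. Also open, as far as these compounds go, is whether the same branching change would read the same on the core of compound 3, which lacks the methoxy groups.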